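Cytotoxicity of a biaryl amide series across aryl exchanges

The compounds below may be only part of what the source reports. "The series", "measured", "known", "first", "only" and "open" are said of these compounds alone.

Of the compounds shown here, three of a shared core have been measured in an ADME assay on HepG2 cells (Homo sapiens) for cytotoxicity, read by CellTiter-Glo and resazurin assay, with a stated time of 72 h; on this read-out higher numbers stand for an effect only at larger amounts of compound and lower numbers for an effect already at smaller amounts. Compound 1 `CCOC(=O)CCCCCOc1cccc(CN(C(=O)c2ccc(-c3cccc4ccccc34)cc2)C(C)C)c1` carries a naphthalen-1-yl group, and in this assay compound 1 reaches only the limit > 26000 nM. Compound 2 `CCOC(=O)CCCCCOc1cccc(CN(C(=O)c2ccc(-c3cccc(NC(C)=O)c3)cc2)C(C)C)c1` bears a 3-acetamidophenyl group in its place, and compound 2 likewise gives only the limit > 26000 nM. Compound 3 `CCOC(=O)CCCCCOc1cccc(CN(C(=O)c2ccc(-c3ccc(Cl)c(Cl)c3)cc2)C(C)C)c1` has a 3,4-dichlorophenyl group, and compound 3 too stops at the limit > 26000 nM. The step that the two limits leave unreadable from compound 1 to compound 2, the step that the two limits leave unreadable from compound 1 to compound 3 and the step that the two limits leave unreadable from compound 2 to compound 3 cannot be sized; all that is known is the limit of > 26000 nM in this assay, at which 3 of the 3 values shown sit. Compound 3 thus stands together with the other two at that limit, with no number of its own.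

Compound 4 `CCOC(=O)CCCCCOc1cccc(CN(C(=O)c2ccc(-c3cccc(S(C)(=O)=O)c3)cc2)C(C)C)c1` differs from compound 3 by 3-(methylsulfonyl)phenyl in place of 3,4-dichlorophenyl on an aromatic carbon. Within the data shown here, none of the measured steps offers a readable size: each of the three exchanges of the aryl group ran between compounds that all sit at the limit. The expectation for compound 4 is that no step beyond the scatter appears in this assay and that the step that the limit leaves unreadable from compound 3 to compound 4 stays small. Compound 4 is estimated at 40000 nM, within 20000 nM to 120000 nM, and is expected most likely to be reported again only as a limit.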

Compound 4, half-maximal effective concentration: > 26000 nM
Compound 4: only a limit was reported; the forecaster's own chance of this, stated with the estimate: 85%; the middle value is on the limit's open side.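

In this assay compound 4 gives > 26000 nM, a limit and not a number. Among these compounds, no step between compound 4 and compound 1, compound 2 or compound 3 can be read, and all that stands is this: the limit of > 26000 nM in this assay, at which 4 of the 4 values shown sit. The compounds shown leave open at what concentration any of the four takes effect, and whether these aryl groups differ at all.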